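The source may report more compounds than this note shows. Statements on the series, on what has been measured and on what is new or still open speak of the compounds shown alone.

Three compounds that share one core have been examined in an ADME assay on L929 cells (Mus musculus) for cytotoxicity, read by resazurin assay, with a stated time of 72 h; on this read-out higher numbers stand for weaker inhibition and lower numbers for stronger inhibition. Compound 1 `O=C(NCc1ccccc1)c1cccn1-c1ccc2c(c1)B(O)OC2` is the simplest of them, and in this assay compound 1 gives > 10 ug/mL, which is a limit of the assay rather than a number. Compound 2 `COc1ccc(CNC(=O)c2cccn2-c2ccc3c(c2)B(O)OC3)cc1` carries a methoxy in place of hydrogen on an aromatic carbon, and in this assay compound 2 gives > 10 ug/mL, again a limit. The step that the two limits leave unreadable from compound 1 to compound 2 therefore cannot be read, because both values sit at the limit of > 10 ug/mL in this assay, at which 3 of the 3 values shown sit.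

Compound 3 `O=C(c1ccn(-c2ccc3c(c2)B(O)OC3)c1)c1ccc(Cl)cc1Cl` changes the way the core is joined to its side group, and in this assay compound 3 gives > 10 ug/mL, a limit once more. So compound 3 stands where every compound shown stands: at a limit, with no number to place it against the others.

Compound 4 `Nc1ccc(C(=O)c2ccn(-c3ccc4c(c3)B(O)OC4)c2)cc1` differs from compound 3 in one place: 4-aminophenyl in place of 2,4-dichlorophenyl on a carbonyl carbon. No measured step touches this change, and the single measured step is unreadable, so nothing shown points to a shift in either direction. The expected step that the limit leaves unreadable from compound 3 to compound 4 is accordingly close to none, and compound 4 is estimated at 12 ug/mL, within a range from 5 ug/mL to 40 ug/mL, most likely again reported as a limit.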

Compound 4, half-maximal inhibitory concentration: 3.9 ug/mL
Beside the measured number, compound 4's estimate is 3.1-fold (0.49 log units) above it; the whole stated range lies above it.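

Within the data shown here, the change from 2,4-dichlorophenyl to 4-aminophenyl on a carbonyl carbon gives an at least 2.5-fold lower number from compound 3 to compound 4 (0.40 log units; beyond the scatter), the first step in this assay that can be read. It shows that the group on this carbonyl carbon can shift the read-out, and since a lower number stands for stronger inhibition, the shift is towards stronger effects on the cells. The size printed is only a minimum, as one end of the step is a limit, and compound 4 is the only compound here that gives a number rather than a limit: the limit of > 10 ug/mL in this assay, at which 3 of the 4 values shown sit.

On these data alone, what stays open is whether the shift comes from the arrival of the amine or from the loss of the two chlorines, and a plain phenyl group on the same carbonyl carbon would help separate those two readings. As far as these compounds go, it is also open whether an amine on the benzyl group of compound 1, whose side group is joined to the shared core differently, would shift the read-out in the same way.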